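The source may report more compounds than this note shows. Statements on the series, on what has been measured and on what is new or still open speak of the compounds shown alone.

Compound 1, `COc1cccc(OC)c1OCCNCCOc1ccccc1OCc1ccc(C)cc1`: 27500 nM
Compound 2, `COc1cccc(OC)c1OCCNCCOc1ccccc1OCc1cccc([N+](=O)[O-])c1`: 38900 nM

In a functional assay on PC-3 cells (Homo sapiens) for cytotoxicity, read by sulforhodamine B assay (on this read-out higher numbers stand for weaker inhibition of growth and lower numbers for stronger inhibition of growth), compound 1 gives 27500 nM and compound 2 gives 38900 nM. Among the compounds with values here, the two numbers lie within the scatter of each other, so compound 2 cannot be told apart from compound 1 on this read-out; the one measured step, a 1.4-fold higher number from compound 1 to compound 2 (0.15 log units; within the scatter), is the only comparison available. Compound 3, `COc1cccc(COc2ccccc2OCCNCCOc2c(OC)cccc2OC)c1`, differs from compound 2 by methoxy in place of nitro on an aromatic carbon. Within the data shown here, no measured step covers this exchange directly; the step from compound 1 to compound 2 changed the ring attached to the same carbon and stayed within the scatter. On that basis the expectation for compound 3 is a step of a 1.2-fold lower number from compound 2 to compound 3 (0.08 log units; within the scatter), not clearly beyond the scatter in either direction. Compound 3 is therefore estimated at 32000 nM, with a range from 12000 nM to 80000 nM.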

Compound 3, concentration for total growth inhibition: 15100 nM
Beside the measured number, compound 3's estimate is 2.1-fold (0.33 log units) above it, within the range that was stated.
By their numbers in this assay, from the lowest: compounds 3, 1 and 2 (each within the scatter of the next, the first and the last beyond it).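

In this assay, within the data shown here, the exchange of nitro for methoxy on this aromatic carbon, meta to a large group, gives the first step beyond the scatter, a 2.6-fold lower number from compound 2 to compound 3 (0.41 log units; beyond the scatter), so a change at this position can move the read-out, if only modestly. The 3-methoxyphenyl and 4-methylphenyl compounds still cannot be told apart, with a 1.8-fold lower number from compound 1 to compound 3 (0.26 log units; within the scatter), so the change registers only against the 3-nitrophenyl compound. Nothing measured here accounts for the size of this step.

On these data alone, it remains open whether other groups on this carbon, such as an amine, a hydroxyl or a carboxylic acid, would extend the step or leave the number within the scatter. As far as these compounds go, it is also open whether methoxy would give the same result on another carbon of this ring.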